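A Methyl Group and Cell Toxicity Across Two Cores

This account rests on a few compounds, and the source may have more. Where it says the series, first, only, none or still open, it means among the compounds named here.

Compound 1 `O=C(Nc1cc(F)c(F)c(F)c1)N1CCCn2ncc(N3CC(c4ccccc4)CC3=O)c2C1` and compound 2 `CC1CCn2ncc(N3CC(c4ccccc4)CC3=O)c2CN1C(=O)Nc1cc(F)c(F)c(F)c1` share one core, while compound 3 `CC1CN(C(=O)Nc2cc(F)c(F)c(F)c2)Cc2c(N3CC(C#N)CC3=O)cnn21` is built on another; the difference between the two cores is not broken down here. In a toxicity assay on HepG2 2.2.15 cells (Homo sapiens) for cytotoxicity, read by CellTiter-Glo (on this read-out higher numbers stand for lower toxicity in this test and lower numbers for higher toxicity in this test), compound 1 gives only a limit of the test, > 2000 nM. In this assay compound 2 likewise gives only a limit, > 2000 nM. Compound 3 gives a real number in this assay, 115000 nM.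

The change from compound 1 to compound 2 is methyl in place of hydrogen on a saturated ring carbon. Its size cannot be read, a step that the two limits leave unreadable from compound 1 to compound 2, because of the limit of > 2000 nM in this assay, at which 2 of the 3 values shown sit.

Compound 4 `CC1(C)CN(C(=O)Nc2cc(F)c(F)c(F)c2)Cc2c(N3CC(C#N)CC3=O)cnn21` has not yet been measured. It differs from compound 3 by methyl in place of hydrogen on a saturated ring carbon. Going by the values given here, this is the same kind of change as the one from compound 1 to compound 2, but not the same change: in compound 4 the methyl sits on a six-membered non-aromatic ring, two ring bonds from the ring nitrogen and two ring bonds from the ring atom that bears a large group, whereas in compound 2 it sits on a seven-membered non-aromatic ring, next to the ring atom that bears a large group and three ring bonds from the ring nitrogen.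

The earlier step of this kind gives no readable size, so the expectation for compound 4 rests on compound 3 alone, whose value 115000 nM is a number rather than a limit. The step from compound 3 to compound 4 is expected to stay within the usual scatter, a 1.3-fold lower number from compound 3 to compound 4 (0.11 log units; within the scatter). Compound 4 is therefore estimated at 90000 nM, with a likely range from 35000 nM to 230000 nM.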

Compound 4, half-maximal cytotoxic concentration: > 200000 nM
Compound 4 gave a limit, no number; the forecaster's own chance of this, stated with the estimate: 15%; middle value at least 2.2-fold (0.34 log units) away from the limit.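

In this assay compound 4 gives > 200000 nM, which is a limit of the test and not a number. On the core of compound 3, the methyl change comes out as an at least 1.7-fold higher number from compound 3 to compound 4 (0.24 log units; that floor lies within the scatter); on this read-out a higher number stands for lower toxicity, but this figure is only a floor, so the true size of the step stays unknown and no shift beyond the usual scatter is shown. The result also does not show whether the change carries over from one core to the other, because the earlier step of this kind, on the core of compound 1, cannot be read and gives nothing to set beside the new one: the limit of > 2000 nM in this assay, at which 2 of the 4 values shown sit.

Still open, from the compounds shown here alone, is how far a larger group on the same saturated ring carbon would move the reading on the core of compound 3, whether a longer chain such as ethyl or a group such as an amine or a carboxylic acid. Also open, going by these compounds, is whether the methyl change has any size of its own on either core, since compound 1, compound 2 and compound 4 each stand at a limit and offer no number to compare.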